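Sulfonyl substituent and passive permeability in an acylsulfonamide series

The source may report more compounds than this note shows. Statements on the series, on what has been measured and on what is new or still open speak of the compounds shown alone.

Measured in a physicochemical assay for permeability, using PAMPA, at pH 7.4; on this read-out lower numbers stand for lower permeability and higher numbers for higher permeability:
- compound 1 `O=C(NS(=O)(=O)c1ccc(F)cc1)c1ccc(Nc2nc(NC3(c4ccc(Cl)cc4)CC3)nc(OCC(F)(F)F)n2)cc1`: 193 nm/s
- compound 2 `CCS(=O)(=O)NC(=O)c1ccc(Nc2nc(NC3(c4ccc(Cl)cc4)CC3)nc(OCC(F)(F)F)n2)cc1`: 28 nm/s
- compound 3 `CC(C)NC(=O)NCCS(=O)(=O)NC(=O)c1ccc(Nc2nc(NC3(c4ccc(Cl)cc4)CC3)nc(OCC(F)(F)F)n2)cc1`: 45 nm/s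

Compound 2 gives the lowest of the three numbers in this assay; compound 3 sits within the scatter of it, and compound 1 stands beyond the scatter above it, a 6.9-fold lower number from compound 1 to compound 2 (0.84 log units; beyond the scatter). Compound 4 `Cc1ccccc1S(=O)(=O)NC(=O)c1ccc(Nc2nc(NC3(c4ccc(Cl)cc4)CC3)nc(OCC(F)(F)F)n2)cc1` is unmeasured. The change is 2-methylphenyl in place of ethyl on a sulfonyl sulfur. Within the data shown here, the only step bearing on it is the reverse-direction exchange at the same sulfonyl sulfur, a 6.9-fold lower number from compound 1 to compound 2 (0.84 log units; beyond the scatter), where an aryl group in place of ethyl carried the higher number. A step of similar size upward is therefore expected, a 5.4-fold higher number from compound 2 to compound 4 (0.73 log units; beyond the scatter), putting compound 4 near compound 1. The estimate for compound 4 in this assay is 150 nm/s, with a range of 60 nm/s to 350 nm/s.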

Compound 4, apparent permeability: 265 nm/s
Estimate against measurement, compound 4: 1.8-fold (0.25 log units) below; the range from low to high includes it.
By their numbers in this assay, from the lowest: compounds 2 and 3 (each within the scatter of the next); then compounds 1 and 4 (each within the scatter of the next).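

In this assay the exchange of ethyl for 2-methylphenyl on the sulfonyl sulfur gives a 9.5-fold higher number from compound 2 to compound 4 (0.98 log units; beyond the scatter) and so repeats, with a second aryl group, the gap seen for 4-fluorophenyl. Exchanging 2-((isopropylcarbamoyl)amino)ethyl for 2-methylphenyl gives a 5.9-fold higher number from compound 3 to compound 4 (0.77 log units; beyond the scatter) in the same direction. The two aryl groups remain unseparated at this position, with a 1.4-fold higher number from compound 1 to compound 4 (0.14 log units; within the scatter) as their whole difference.

On these data alone, whether a pyridyl ring or a longer alkyl chain such as n-butyl on the sulfonyl sulfur would fall with the aryl groups or with ethyl remains open. Nothing available explains the gap between the aryl and alkyl groups.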